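Fluoro for hydrogen on the core of compound 1

The compounds below may be only part of what the source reports. "The series", "measured", "known", "first", "only" and "open" are said of these compounds alone.

Measured so far:
compound 1 `c1ccc2c(C3CC(c4ccncc4)=NO3)c[nH]c2c1` — 19700 nM
compound 2 `COc1ccc2[nH]cc(C3CC(c4ccncc4)=NO3)c2c1` — > 100000 nM

Going by the values given here, compound 1 `c1ccc2c(C3CC(c4ccncc4)=NO3)c[nH]c2c1` carries the only number in a functional assay on MDA-MB-231 cells (Homo sapiens) for inhibition, read by MTT assay, with a stated time of 48 h (a lower number here means a stronger inhibitor, a higher number a weaker inhibitor), where compound 1 gives 19700 nM. Compound 2 `COc1ccc2[nH]cc(C3CC(c4ccncc4)=NO3)c2c1` gives only a limit of this assay, > 100000 nM, and sits at the limit of > 100000 nM in this assay, at which 1 of the 2 values shown sits. Among the compounds with values here, the one measured step, methoxy in place of hydrogen on an aromatic carbon, is an at least 5.0-fold higher number from compound 1 to compound 2 (0.70 log units; beyond the scatter).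

Compound 3 `Fc1ccc2c(C3CC(c4ccncc4)=NO3)c[nH]c2c1` is not yet measured. It differs from compound 1 by fluoro in place of hydrogen on an aromatic carbon. Within the data shown here, the only step in hand concerns a different group, methoxy, and it weakened the compound at least modestly; it is the sole guide for the fluoro change and a loose one. For compound 3 a step of no more than modest size is expected in this assay, most likely none beyond the scatter, with a weakening the more probable direction if any, so that the expected change is a 1.3-fold higher number from compound 1 to compound 3 (0.10 log units; within the scatter). Compound 3 is therefore estimated at 25000 nM, within 8000 nM to 80000 nM.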

Compound 3, half-maximal inhibitory concentration: 5000 nM
Compound 3: middle estimate off by 5.0-fold (0.70 log units), on the high side, outside the stated range (below it).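

In this assay the six-membered aromatic ring of the shared core accepts a substituent with a gain: fluoro in place of hydrogen gives a 3.9-fold lower number from compound 1 to compound 3 (0.60 log units; beyond the scatter). Substitution on this ring therefore does not act in one direction only, as the sole earlier step, an at least 5.0-fold higher number from compound 1 to compound 2 (0.70 log units; beyond the scatter), ran the other way and rests on a limit of the assay for compound 2; that step, however, involves a different group on a different ring carbon, so the two steps do not separate the effect of the group from that of its place. Nothing measured here bears on why the fluoro change lowers the number.

Open, as far as these compounds go, is whether the gain belongs to fluoro itself or to this ring carbon, a question that chloro or methyl on the same carbon, and fluoro on the carbon that carries methoxy in compound 2, would address. Also open, from the compounds shown here alone, is how far this carbon tolerates larger or charged groups, such as trifluoromethyl, an amine or a carboxylic acid.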